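Acetamido for Dimethylamino on Two Naphthalene-Derived Sulfonamide Cores

This account rests on a few compounds, and the source may have more. Where it says the series, first, only, none or still open, it means among the compounds named here.

Compound 1 `Cc1noc(NS(=O)(=O)c2cccc3cc(N(C)C)ccc23)c1C` was tested in an assay on thoracic aorta for binding affinity to Endothelin-1 receptor (Rattus norvegicus) (a higher number here means a weaker inhibitor, a lower number a stronger inhibitor), and compound 1 gives 840 nM. Compound 2 `CC(=O)Nc1ccc2c(S(=O)(=O)Nc3onc(C)c3C)cccc2c1` carries the change (acetamido in place of dimethylamino on an aromatic carbon), and in this assay compound 2 gives 1300 nM; the step is a 1.5-fold higher number from compound 1 to compound 2 (0.19 log units; within the scatter). Compound 3 `Cc1noc(NS(=O)(=O)c2ccc3cccc(N(C)C)c3c2)c1C` has the same atoms as compound 1 joined differently, a difference between the two cores that is not broken down here; in this assay compound 3 gives 31500 nM. Compound 4 `CC(=O)Nc1cccc2ccc(S(=O)(=O)Nc3onc(C)c3C)cc12` is not yet measured and differs from compound 3 by acetamido in place of dimethylamino on an aromatic carbon. This is the same kind of change as that from compound 1 to compound 2, though the place is ortho and meta to a fused ring rather than meta and para to it. Because a 1.5-fold higher number from compound 1 to compound 2 (0.19 log units; within the scatter) lay within the scatter, the step is expected to be small, about a 1.3-fold higher number from compound 3 to compound 4 (0.10 log units; within the scatter). Compound 4 is therefore estimated at 40000 nM, between 14000 nM and 110000 nM.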

Compound 4, half-maximal inhibitory concentration: 27500 nM
Beside the measured number, compound 4's estimate is 1.5-fold (0.16 log units) above it, within the range that was stated.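

In this assay, acetamido in place of dimethylamino on the core of compound 3 gives a 1.1-fold lower number from compound 3 to compound 4 (0.06 log units; within the scatter). The two steps agree across the cores: the same change on two cores in this assay, a 1.5-fold higher number (0.19 log units; within the scatter) from compound 1 to compound 2 and a 1.1-fold lower number (0.06 log units; within the scatter) from compound 3 to compound 4, 1.8-fold (0.25 log units) apart, within the scatter of two such steps. This shows that the exchange carried over between these two cores without a step beyond the scatter, but it does not show that the same would hold on any other core, and it says nothing about what sets the two cores apart.

The compounds shown leave open whether a free amine, a carboxylic acid or a longer acyl chain on the same aromatic carbon would read like acetamido and dimethylamino.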